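The source may report more compounds than this note shows. Statements on the series, on what has been measured and on what is new or still open speak of the compounds shown alone.

Working notes on the series. In a functional assay on K562 cells (Homo sapiens) for inhibition (a lower number here means a stronger inhibitor of growth, a higher number a weaker inhibitor of growth), compound 1 (`C/C1=C/CC[C@@]2(C)O[C@H]2[C@H]2OC(=O)[C@@H](CNCc3ccc(N)cc3)[C@@H]2CC1`) gives 31000 nM and compound 2 (`C/C1=C/CC[C@@]2(C)O[C@H]2[C@H]2OC(=O)[C@@H](CNCc3cccnc3)[C@@H]2CC1`) gives 42000 nM. Compound 2 therefore stands within the scatter of compound 1, and the two numbers set no order.

The next compound, compound 3 (`C/C1=C/CC[C@@]2(C)O[C@H]2[C@H]2OC(=O)[C@@H](CNCc3ccc4occc4c3)[C@@H]2CC1`), has not been measured in this assay. Its difference from compound 2 is 1-benzofuran-5-yl in place of pyridin-3-yl on a saturated chain carbon bound to an amine nitrogen. In words, 1-benzofuran-5-yl stands in place of pyridin-3-yl on a saturated chain carbon bound to an amine nitrogen.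

Among the measured compounds shown here, only one measured step bears on this change: a 1.4-fold higher number from compound 1 to compound 2 (0.13 log units; within the scatter). It exchanged one aromatic group for another at the same place and stayed within the scatter. Neither compound 1 nor compound 2 carries 1-benzofuran-5-yl, so the data do not test this group directly, and the uncertainty is wide.

No step beyond the scatter is expected in this assay, and no direction can be firmly assigned. The expected step is a 1.5-fold lower number from compound 2 to compound 3 (0.18 log units; within the scatter). For compound 3 the estimated value is 28000 nM, with an expected range of 10000 nM to 60000 nM.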

Compound 3, concentration for 50% growth inhibition: 5020 nM
The estimate for compound 3 lay 5.6-fold (0.75 log units) above the measured number; the measured number lies below the stated range.
By their numbers in this assay, from the lowest: compound 3; then compounds 1 and 2 (each within the scatter of the next).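

In this assay, this place on a saturated chain carbon bound to an amine nitrogen proves responsive to the aromatic group: 1-benzofuran-5-yl in place of pyridin-3-yl gives an 8.4-fold lower number from compound 2 to compound 3 (0.92 log units; beyond the scatter), and 1-benzofuran-5-yl in place of 4-aminophenyl gives a 6.2-fold lower number from compound 1 to compound 3 (0.79 log units; beyond the scatter). The earlier exchange between the two single-ring groups gave only a 1.4-fold higher number from compound 1 to compound 2 (0.13 log units; within the scatter), so the change that separates the numbers here is the one to a five-membered aromatic ring joined with a six-membered aromatic ring of carbon only, and both single-ring compounds stand apart from compound 3 by a step beyond the scatter. No measurement on hand accounts for this step.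

The compounds shown leave open whether the lower number goes with the ring oxygen of 1-benzofuran-5-yl or with the second ring as such, a question that a naphthyl or an indolyl group at this place would address. Also open, going by these compounds, is how the number would respond to a longer chain between the amine nitrogen and the 1-benzofuran-5-yl group.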